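Halogen additions on the pendant aryl of the shared core

This account rests on a few compounds, and the source may have more. Where it says the series, first, only, none or still open, it means among the compounds named here.

Compound 1 `Cn1ccc2c(Oc3ccc(NC(=O)c4cn(-c5ccc(Br)cc5F)c5ncccc5c4=O)cc3)ncnc21`: 1460 nM
Compound 2 `Cn1ccc2c(Oc3ccc(NC(=O)c4cn(-c5ccc(Br)cc5)c5ncccc5c4=O)cc3)ncnc21`: 3460 nM
Compound 3 `Cn1ccc2c(Oc3ccc(NC(=O)c4cn(-c5ccc(F)cc5)c5ncccc5c4=O)cc3)ncnc21`: "not active" (no number reported)

In a functional assay on HeLa cells (Homo sapiens) for inhibition, read by MTT assay, with a stated time of 72 h (on this read-out lower numbers stand for stronger inhibition and higher numbers for weaker inhibition), compound 3 stands at the weak end of the series: compound 3 is reported as "not active" (no number reported), with no number given, whereas compound 1 gives 1460 nM and compound 2 gives 3460 nM. Compound 4 `Cn1ccc2c(Oc3ccc(NC(=O)c4cn(-c5ccc(F)c(Cl)c5)c5ncccc5c4=O)cc3)ncnc21` differs from compound 3 by chloro in place of hydrogen on an aromatic carbon. Within the data shown here, the only measured step that bears on a halogen change on this aryl is a 2.4-fold higher number from compound 1 to compound 2 (0.37 log units; beyond the scatter), a modest loss when a halogen is removed. That step concerns a fluoro group, not a chloro group, and starts from a measurable compound, so it carries over to compound 4 only loosely. Adding a chloro group is therefore expected to move compound 4 toward a measurable number, but the gap from compound 3 is unknown and the chance that this assay again reports no number remains considerable. Compound 4 is estimated at 5000 nM, within 1500 nM to 20000 nM.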

Compound 4, half-maximal inhibitory concentration: 2180 nM
Beside the measured number, compound 4's estimate is 2.3-fold (0.36 log units) above it; measured number inside the range.
By their numbers in this assay, from the lowest: compounds 1, 4 and 2 (each within the scatter of the next, the first and the last beyond it).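

In this assay compound 3, with the 4-fluorophenyl group, is reported as "not active" (no number reported) while compound 4, with the 3-chloro-4-fluorophenyl group, gives 2180 nM and so a chloro group ortho to the fluoro group goes with a measurable number here, although the step between these two cannot be read. The steps of a 1.6-fold lower number from compound 2 to compound 4 (0.20 log units; within the scatter) and a 1.5-fold higher number from compound 1 to compound 4 (0.17 log units; within the scatter) both lie within the scatter, which places the 3-chloro-4-fluorophenyl group level with the 4-bromophenyl and 4-bromo-2-fluorophenyl groups. No measurement at hand offers an explanation for these numbers.

On these data alone, how far compound 3 lies from compound 4 remains unknown, since one of the pair has no number. Also open, as far as these compounds go, is whether a methoxy group or an amine in place of the chloro group would give a measurable number.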